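The source may report more compounds than this note shows. Statements on the series, on what has been measured and on what is new or still open speak of the compounds shown alone.

Measured compounds:
compound 1, `CC(C)(C)c1cnc(CCc2ccc(-c3ccccc3C(=O)O)cc2)[nH]1`: 2750 nM
compound 2, `O=C(O)c1ccccc1-c1ccc(CCc2ncc(Cc3ccccc3Cl)[nH]2)cc1`: 22 nM

For the measured compounds named here, in an in vitro functional assay on cells for agonist activity at Bombesin receptor subtype-3 (Mus musculus), read by luminescence and calcium flux (on this read-out lower numbers stand for an effect already at smaller amounts and higher numbers for an effect only at larger amounts of compound), compound 2 gives 22 nM, the lowest of the two numbers so far; its nearest neighbour is compound 1, which in this assay gives 2750 nM. Going by the values given here, the single step between measured compounds, a 130-fold lower number from compound 1 to compound 2 (2.10 log units; beyond the scatter), is the 2-chlorobenzyl in place of tert-butyl on an aromatic carbon. Compound 3, `Cc1ccccc1Cc1cnc(CCc2ccc(-c3ccccc3C(=O)O)cc2)[nH]1`, keeps that benzyl arm and differs from compound 2 only by methyl in place of chloro on an aromatic carbon, on an aromatic carbon of a six-membered aromatic ring of carbon only, ortho to a large group. Among the compounds with values here, no measured step compares two substituents on that ring: the step from compound 1 to compound 2 shows that the arm as a whole brings the large gain, but it does not separate the chloro from the rest of the 2-chlorobenzyl. With no ring, donor, acceptor or charge entering or leaving, for compound 3 the step expected in this assay is small, a 1.8-fold higher number from compound 2 to compound 3 (0.26 log units; within the scatter), within or near the scatter, possibly toward a slightly higher number. Compound 3 is estimated at 40 nM, with a range of 12 nM to 130 nM.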

Compound 3, half-maximal effective concentration: 9.3 nM
Estimate against measurement, compound 3: 4.3-fold (0.63 log units) above, and the stated range ends above it.
By their numbers in this assay, from the lowest: compound 3; then compound 2; then compound 1.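

In this assay, for the compounds shown here, the step from chloro to methyl on an aromatic carbon of a six-membered aromatic ring of carbon only, ortho to a large group, is a 2.4-fold lower number from compound 2 to compound 3 (0.37 log units; beyond the scatter), the first direct reading of a substituent at this place, and it shows that the two groups are not interchangeable here, with the 2-methylbenzyl arm ahead of the 2-chlorobenzyl arm. The large gain over tert-butyl does not depend on chloro, since the 2-methylbenzyl arm gives a 300-fold lower number from compound 1 to compound 3 (2.47 log units; beyond the scatter) and so keeps that gain with no halogen on the arm. Nothing measured on these compounds bears on the reason for the difference between methyl and chloro.

The compounds shown leave open whether this place needs a substituent at all, as a plain benzyl arm would show, and whether an ethyl, methoxy or trifluoromethyl group there would go beyond methyl or fall back. Also open, going by these compounds, are whether methyl on another carbon of that ring would serve as well, and whether methyl stays ahead of chloro with a tetrazole in place of the carboxylic acid.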